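The source may report more compounds than this note shows. Statements on the series, on what has been measured and on what is new or still open speak of the compounds shown alone.

Three compounds have been measured in a functional assay on WI-38 VA13 cells (Homo sapiens) for cytotoxicity; a higher number here means that more compound is needed for the effect, a lower number that less compound is needed:

compound 1, `O=C(Nc1ccc2nc(NC(=O)C3CCCCC3)sc2c1)c1ccccc1C(F)(F)F`, 0.024 ug/mL
compound 2, `CC(=O)Nc1ccc2nc(NC(=O)C3CCCCC3)sc2c1`, 2.7 ug/mL
compound 3, `O=C(Nc1ccc2nc(NC(=O)C3CCC3)sc2c1)c1c(Cl)cccc1Cl`, 0.013 ug/mL

Compound 3 gives the lowest of the three numbers. Its nearest neighbour is compound 1, whose number lies within the scatter of compound 3, so the two cannot be ranked against each other; the furthest is compound 2, whose number lies beyond the scatter. Going by the values given here, the only step between compounds differing in one place is a 110-fold higher number from compound 1 to compound 2 (2.05 log units; beyond the scatter), and it concerns the group on the other carbonyl carbon, the one attached to the aromatic ring of the shared core.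

Compound 4, `COCCOC(=O)Nc1nc2ccc(NC(=O)c3c(Cl)cccc3Cl)cc2s1`, differs from compound 3 in one place: 2-methoxyethoxy in place of cyclobutyl on a carbonyl carbon. Among the compounds with values here, no measured step alters the group on this carbonyl carbon alone. Compound 1 and compound 3 differ there as well as elsewhere, and their two values lie within the scatter of each other, which gives a weak hint that this position tolerates change. Within the data shown here, with no direct precedent, a small step to a somewhat higher number is expected, a 2.3-fold higher number from compound 3 to compound 4 (0.36 log units; beyond the scatter), with a wide range. Compound 4 is therefore estimated at 0.03 ug/mL, between 0.006 ug/mL and 0.2 ug/mL.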

Compound 4, half-maximal effective concentration: 0.011 ug/mL
Beside the measured number, compound 4's estimate is 2.7-fold (0.44 log units) above it, within the range that was stated.
By their numbers in this assay, from the lowest: compounds 4, 3 and 1 (each within the scatter of the next, the first and the last beyond it); then compound 2.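

In this assay the exchange of cyclobutyl for 2-methoxyethoxy on this carbonyl carbon gives a 1.2-fold lower number from compound 3 to compound 4 (0.07 log units; within the scatter) and so the two compounds cannot be ranked against each other. This direct comparison shows that, with the rest of the molecule held constant, a four-membered carbon ring can give way to an open chain carrying 2 hydrogen-bond acceptors without a change beyond the scatter, which is firmer than the earlier hint from two compounds differing in more than one place. No measurement shown here gives a reason for this result.

From the compounds shown here alone, whether this carbonyl carbon also accepts a group bearing an amine, a carboxylic acid or a much longer chain remains open. Also open, going by these compounds, is whether 2-methoxyethoxy would give a similar result alongside the methyl of compound 2 instead of the dichlorophenyl group of compound 4.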